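Cyclopentyl in place of methyl on the sulfonamide nitrogen

The source may report more compounds than this note shows. Statements on the series, on what has been measured and on what is new or still open speak of the compounds shown alone.

In a physicochemical assay for solubility, in phosphate buffer, measured as kinetic solubility, at pH 7.4, tested at 250 uM (a lower number here means a less soluble compound, a higher number a more soluble compound), compound 1 `CCCCCCNc1ccc([N+](=O)[O-])cc1S(N)(=O)=O` gives 6000 nM and stands well under the other two measured compounds. Compound 2 `CCCCCCNc1ccc(C(=O)O)cc1S(=O)(=O)NC` gives 247000 nM and compound 3 `CNS(=O)(=O)c1cc(C(=O)O)ccc1NCCCCCCCC(F)(F)F` gives 242000 nM and these two sit level with each other at the top of the series.

The change to compound 4 `O=C(O)c1ccc(NCCCCCCCC(F)(F)F)c(S(=O)(=O)NC2CCCC2)c1` is cyclopentyl in place of methyl on a sulfonamide nitrogen and puts cyclopentyl in place of methyl on a sulfonamide nitrogen of compound 3. Among the compounds with values here, only one measured step bears on it, and only loosely: a 1.0-fold lower number from compound 2 to compound 3 (0.01 log units; within the scatter) stays within the scatter, yet it lies on the chain and not on the sulfonamide nitrogen. Compound 1 differs from compound 2 in more than one place and does not isolate this change. Within the data shown here, no measured step alters the group on that nitrogen alone.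

In this assay the expected step is a 1.3-fold lower number from compound 3 to compound 4 (0.13 log units; within the scatter) and so none beyond the scatter. Compound 4 is expected at 180000 nM within an estimated range from 70000 nM to 260000 nM as a working figure.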

Compound 4, solubility: 223000 nM
Compound 4: the middle estimate sits 1.2-fold (0.09 log units) below what was measured; the measured number falls inside the stated range.
By their numbers in this assay, from the lowest: compound 1; then compounds 4, 3 and 2 (each within the scatter of the next).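

In this assay, cyclopentyl in place of methyl on the sulfonamide nitrogen gives a 1.1-fold lower number from compound 3 to compound 4 (0.04 log units; within the scatter), the only step shown that changes the group on this nitrogen alone. Compound 2 and compound 3 both carry methyl there, so they could not show how a ring at this position reads; this step shows that the change from methyl to cyclopentyl, on the chain of compound 3, stays within the scatter. No measurement shown here gives a reason for this result.

Open, on these data alone, is whether other groups on the sulfonamide nitrogen, such as a longer chain, a six-membered ring of carbon only or a ring bearing an amine, would also stay within the scatter. Also open, as far as these compounds go, is whether cyclopentyl gives a step of this size with the chain of compound 2.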